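The source may hold more compounds than are shown below. What is called first, only, known or untested is meant among the compounds shown, and "the series" means these compounds.

Measured in a toxicity assay on MDCK cells (Canis lupus familiaris) for cytotoxicity, read by crystal violet staining, with a stated time of 48 h; a lower number here means that less compound is tolerated, a higher number that more compound is tolerated:
compound 1, `Cc1ccc2cc(CN(Cc3ccc(C(C)(C)C)cc3)CC3CCCCC3)c(=O)[nH]c2c1`: > 10000 nM
compound 2, `COc1ccc(CN(Cc2ccc(C(C)(C)C)cc2)Cc2cc3cc(C)ccc3[nH]c2=O)cc1`: > 10000 nM

The value shown for compound 1 is a limit of this assay, not a number. The value shown for compound 2 is likewise a limit of this assay, not a number. Both values sit at the limit of > 10000 nM in this assay, at which 2 of the 2 values shown sit, so compound 2 stands at the same limit as compound 1 and cannot be ranked against it. For the measured compounds named here, no step between measured compounds is available, and the two values give no direction.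

Compound 3, `Cc1ccc2[nH]c(=O)c(CN(Cc3ccc(C#N)cc3)Cc3ccc(C(C)(C)C)cc3)cc2c1`, is not yet measured in this assay. It differs from compound 2 by cyano in place of methoxy on an aromatic carbon. With both measured compounds at the limit, no step beyond the scatter is expected for this change, a step that the limit leaves unreadable from compound 2 to compound 3. Compound 3 is expected to sit at the limit of this assay as well, with an estimate of 15000 nM and a range from 8000 nM to 40000 nM.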

Compound 3, half-maximal cytotoxic concentration: > 5000 nM
Compound 3 ended at the assay's limit; the forecaster's own chance of this, stated with the estimate: 85%; the middle value is on the limit's open side.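

Compound 2 and compound 3 both stand at limits of the assay, not at numbers, so no step can be read for cyano in place of methoxy. The compounds shown leave open whether the 4-methoxybenzyl and 4-cyanobenzyl compounds differ at all in this assay, and where any actual half-maximal cytotoxic concentration in this series lies.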